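A few compounds are considered here, and "the series" means these few. Any claim that something is new, unique, unknown or untested is made for them only; others in the source may bear on it.

Measured so far:
Compound 1, `COC(=O)c1c(Nc2ccc(OC)cc2)sc(C(=O)c2ccc(OC)cc2)c1C`: 15.5%
Compound 2, `COC(=O)c1c(Nc2ccc(F)cc2)sc(C(=O)c2ccc(OC)cc2)c1C`: 20.2%
Compound 3, `COc1ccc(Nc2sc(C(=O)c3ccc(OC)cc3)c(C)c2C(=O)O)cc1`: 38.5%

The three compounds were tested in a functional assay, with a stated time of 150 min, tested at 25 ug/mL; a higher number here means a stronger effect of the compound at the concentration tested, a lower number a weaker effect. Compound 4, `COc1ccc(C(=O)c2sc(Nc3ccc(F)cc3)c(C(=O)O)c2C)cc1`, has not yet been measured there.

Compound 2 differs from compound 1 by fluoro in place of methoxy on an aromatic carbon, and in this assay that change gave a number 4.7 percentage points higher from compound 1 to compound 2 (within the scatter). Compound 3 differs from compound 1 in the core by hydrogen in place of methyl on an oxygen next to a carbonyl group, which gave a number 23 percentage points higher from compound 1 to compound 3 (beyond the scatter); compound 3 is the highest of the three, and its margins over compound 2 and compound 1 are both beyond the scatter.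

Compound 4 differs from compound 3 by fluoro in place of methoxy on an aromatic carbon. This is the same change that leads from compound 1 to compound 2, made on the core of compound 3. Because that change gave a number 4.7 percentage points higher from compound 1 to compound 2 (within the scatter), a step of similar size is expected here, and the estimate is a number 3.5 percentage points higher from compound 3 to compound 4 (within the scatter); it rests on a single earlier example and is therefore uncertain. Compound 4 is expected to give about 42%, between 30% and 55%.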

Compound 4, a percentage reported as activity, at one concentration (the size of the read-out at that concentration, not a potency): 0.836%
Beside the measured number, compound 4's estimate is 41.2 percentage points above it, outside the stated range (below it).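

In this assay, fluoro in place of methoxy did not behave alike on the two cores, and here it gave a number 37.7 percentage points lower from compound 3 to compound 4 (beyond the scatter): the same change on two cores in this assay, a number 4.7 percentage points higher (within the scatter) from compound 1 to compound 2 and a number 37.7 percentage points lower (beyond the scatter) from compound 3 to compound 4, 42.4 percentage points apart, beyond the scatter of two such steps. Seen from the other direction, hydrogen in place of methyl on an oxygen next to a carbonyl group gave a number 19.4 percentage points lower from compound 2 to compound 4 (beyond the scatter), which reverses the direction of the earlier step: the same change on two cores in this assay, a number 23 percentage points higher (beyond the scatter) from compound 1 to compound 3 and a number 19.4 percentage points lower (beyond the scatter) from compound 2 to compound 4, 42.4 percentage points apart, beyond the scatter of two such steps. Neither change can therefore be carried from one core to the other in this series as a fixed step, but these four compounds do not show why the two changes fail to add up, or whether the same holds for any other pair of groups.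

Only methoxy and fluoro are shown at this place, so what a chloro group, a methyl group or an unsubstituted phenyl ring would do there remains open. Also open, as far as these compounds go, is how an amide or a longer ester chain would behave in place of the carboxylic acid.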